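Bromo to iodo in the halogen series

A few compounds are considered here, and "the series" means these few. Any claim that something is new, unique, unknown or untested is made for them only; others in the source may bear on it.

In a functional assay on NCI-H460 cells (Homo sapiens) for cytotoxicity, read by sulforhodamine B assay, with a stated time of 3 days (on this read-out higher numbers stand for weaker inhibition and lower numbers for stronger inhibition), compound 1 `OCc1cn(Cc2cccc(Cl)c2)c2ccccc12` gives 19 nM, and compound 2 `OCc1cn(Cc2cccc(Br)c2)c2ccccc12` gives 28 nM. Among the compounds with values here, compound 2 thus stands within the scatter of compound 1, its only measured neighbour, and the two cannot be separated on this read-out.

Compound 3 `OCc1cn(Cc2cccc(I)c2)c2ccccc12` keeps the shared core and differs from compound 2 in one place: iodo in place of bromo on an aromatic carbon of a six-membered aromatic ring of carbon only, meta to a large group. Within the data shown here, no iodo compound has been measured yet. Among the measured compounds shown here, the one measured step bearing on this change is a 1.5-fold higher number from compound 1 to compound 2 (0.17 log units; within the scatter), likewise an exchange of one halogen for another. On the basis of that single step, no change beyond the scatter is expected in this assay, although one step is thin evidence. The expected step is a 1.1-fold higher number from compound 2 to compound 3 (0.03 log units; within the scatter). For compound 3 the estimated value is 30 nM, with an expected range from 14 nM to 65 nM.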

Compound 3, half-maximal inhibitory concentration: 100 nM
Compound 3: middle estimate off by 3.3-fold (0.52 log units), on the low side; the whole stated range lies below it.
By their numbers in this assay, from the lowest: compounds 1 and 2 (each within the scatter of the next); then compound 3.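

With a 3.6-fold higher number from compound 2 to compound 3 (0.55 log units; beyond the scatter) for iodo in place of bromo and a 5.3-fold higher number from compound 1 to compound 3 (0.72 log units; beyond the scatter) for iodo in place of chloro, the halogen at this position on the six-membered aromatic ring of carbon only is shown to matter in this assay, which the earlier pair could not show. Within the data shown here, compound 1 and compound 2 remain within the scatter of each other, and compound 3 alone stands apart, on the side of weaker inhibition, so the series tolerates exchange between these halogens only as far as bromo, and the silent step from chloro to bromo gave no warning of the step to iodo. The compounds shown offer no measurement that accounts for this separation of the iodo compound.

Going by these compounds, whether iodo would cost as much at another place on this ring remains open, since all three compounds carry their halogen at the same place. Also open, on these data alone, is whether a group other than a halogen at this place, such as methyl, methoxy or a nitrile, would read with compound 1 and compound 2 or with compound 3.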